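The source may hold more compounds than are shown below. What is called first, only, known or untested is meant among the compounds shown, and "the series" means these compounds.

Working notes on the series. In an ADME assay on HEK293 cells (Homo sapiens) for cytotoxicity, with a stated time of 72 h (on this read-out higher numbers stand for an effect only at larger amounts of compound and lower numbers for an effect already at smaller amounts), compound 1 `Cc1cc(NC(=O)Nc2cccc(F)c2)c2ccccc2n1` gives > 25000 nM, which is a limit of the assay and not a number. Compound 2 `CSc1ccccc1NC(=O)Nc1cc(C)nc2ccccc12` gives > 25000 nM, again a limit of the assay. Going by the values given here, compound 3 `Cc1cc(NC(=O)Nc2ccc(F)cc2F)c2ccccc2n1` gives 10000 nM, the only true number in the set, so it has no measured neighbour to be ranked against.

The next compound is compound 4 `Cc1cc(NC(=O)Nc2ccccc2F)c2ccccc2n1`, and the change from compound 3 is hydrogen in place of fluoro on an aromatic carbon. In short, hydrogen stands in place of fluoro on an aromatic carbon. Among the compounds with values here, no measured pair isolates this change. The expectation therefore leans on (the limit of > 25000 nM in this assay, at which 2 of the 3 values shown sit), which favours a shift towards larger amounts, with a fair chance that compound 4 also reaches the limit. In this assay, the expected step of a 2.0-fold higher number from compound 3 to compound 4 (0.30 log units; within the scatter) is small, towards larger amounts, and close to the usual scatter. For compound 4 the estimate is 20000 nM, with an expected range from 9000 nM to 40000 nM.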

Compound 4, half-maximal effective concentration: > 25000 nM
Compound 4: no number, only a limit (the forecaster's own chance of this, stated with the estimate: 55%); middle value at least 1.2-fold (0.09 log units) away from the limit.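

In this assay, going by these compounds alone, the fluoro on the aromatic carbon meta to a fluoro group and para to a large group gives the first single change that can be read, and replacing it with hydrogen gives an at least 2.5-fold higher number from compound 3 to compound 4 (0.39 log units; beyond the scatter). Within the data shown here, in this one pair, the fluoro at this position separates the only compound with a true number from a compound at the limit, and the step gives only a lower bound on the size of the change, while the steps from compound 1 and from compound 2 to compound 4 join two limits and cannot be read. Compound 4 now sits with compound 1 and compound 2 at the limit of the assay: the limit of > 25000 nM in this assay, at which 3 of the 4 values shown sit.

From the compounds shown here alone, how chloro, methoxy or an amine at this position would compare with fluoro stays open. So does whether the same replacement has a readable effect elsewhere on the aromatic ring.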